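The source may hold more compounds than are shown below. What is called first, only, known or untested is meant among the compounds shown, and "the series" means these compounds.

In a functional assay on SW480 cells (Homo sapiens) for antiproliferative activity, read by MTT assay, with a stated time of 72 h (a lower number here means a stronger inhibitor, a higher number a weaker inhibitor), compound 2 `COc1ccc2occ(CSC(=S)N(C(C)C)C(C)C)c(=O)c2c1` gives 4800 nM. For compound 1 `Cc1ccc2c(=O)c(CSC(=S)N(C(C)C)C(C)C)coc2c1` the value > 25000 nM is a limit of the assay, not a number. For compound 3 `CC(C)N(C(=S)SCc1coc2cc(Cl)ccc2c1=O)C(C)C` the value > 25000 nM is likewise only a limit. The step that the two limits leave unreadable from compound 1 to compound 3 therefore has no readable size, both ends resting on (the limit of > 25000 nM in this assay, at which 2 of the 3 values shown sit). Compound 3 thus stands at the weak end of what is shown, with only a limit to its name. Compound 4 `CC(C)N(C(=S)SCc1coc2ccccc2c1=O)C(C)C` differs from compound 3 by hydrogen in place of chloro on an aromatic carbon. Within the data shown here, no measured step in this assay bears on this change, so neither direction nor size can be drawn from the measured pairs. Compound 4 is expected to give 20000 nM, between 5000 nM and 60000 nM, with the expected step of an at least 1.2-fold lower number from compound 3 to compound 4 (0.09 log units; that floor lies within the scatter) not beyond the scatter.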

Compound 4, half-maximal inhibitory concentration: 6800 nM
Estimate against measurement, compound 4: 2.9-fold (0.47 log units) above, within the range that was stated.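

In this assay, hydrogen in place of chloro gives an at least 3.6-fold lower number from compound 3 to compound 4 (0.56 log units; beyond the scatter), and hydrogen in place of methyl gives an at least 3.6-fold lower number from compound 1 to compound 4 (0.56 log units; beyond the scatter), so on this aromatic carbon both changes now have a readable direction. Hydrogen in place of methoxy, by contrast, gives a 1.4-fold higher number from compound 2 to compound 4 (0.15 log units; within the scatter), which separates neither compound from the other. The first two sizes are only floors, as compound 1 and compound 3 rest on a limit: the limit of > 25000 nM in this assay, at which 2 of the 4 values shown sit.

From the compounds shown here alone, how far those two compounds truly lie from compound 4 stays open. So does what an amine or a carboxylic acid on this aromatic carbon would give.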